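Replacing a Chlorophenyl Amide with Isopropyl

This account rests on a few compounds, and the source may have more. Where it says the series, first, only, none or still open, it means among the compounds named here.

compound 1 `Cc1cccc(Cn2c(OC3CCN(C(=O)c4ccco4)CC3)nc3ccccc32)c1`: 68.3%
compound 2 `O=C(C1CC1)N1CCN(Cc2nc3ccccc3n2Cc2ccccc2F)CC1`: 40.7%
compound 3 `Cc1cccc(Cn2c(CN3CCN(C(=O)c4ccc(Cl)cc4)CC3)nc3ccccc32)c1`: 23.2%

In an assay on isolated protein for inhibition of aldehyde dehydrogenase 1A1 (Homo sapiens), read by spectrophotometry, tested at 10 uM (on this read-out lower numbers stand for less inhibition and higher numbers for more inhibition at the one concentration tested (going by the name of the read-out)), compound 3 stands lowest of the three measured compounds; its nearest neighbour is compound 2, whose reading is higher by a margin beyond the scatter, and compound 1 lies furthest above it. Compound 4 `Cc1cccc(Cn2c(CN3CCN(C(=O)C(C)C)CC3)nc3ccccc32)c1` has not yet been measured. It differs from compound 3 in one place: isopropyl in place of 4-chlorophenyl on a carbonyl carbon. For the measured compounds named here, no measured pair shows this change on its own, so its effect in this assay is not known from these data. Compound 2 gives a higher reading than compound 3, but it differs from compound 3 in more than one place. A modest step upward, near the edge of the scatter, is expected a number 6.8 percentage points higher from compound 3 to compound 4 (within the scatter). Compound 4 is estimated at 30%, with a range from 10% to 55%.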

Compound 4, a percentage reported as inhibition, at one concentration (the size of the read-out at that concentration, not a potency): 87.2%
Compound 4: middle estimate off by 57.2 percentage points, on the low side, and the stated range ends below it.
By their numbers in this assay, from the lowest: compound 3; then compound 2; then compound 1; then compound 4.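

Isopropyl in place of 4-chlorophenyl on a carbonyl carbon gives a number 64 percentage points higher from compound 3 to compound 4 (beyond the scatter) in this assay. This first single-change pair shows that the group at this position strongly affects the reading and that an aromatic ring is not needed there for inhibition at the one concentration tested. Nothing here gives a measured explanation for the step.

Going by these compounds, whether the loss of the chlorine or of the ring matters more remains open, and a plain phenyl on this carbonyl carbon would separate the two. On these data alone, how a longer chain such as n-butyl or a carboxylic acid would fare there also remains open.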